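A few compounds are considered here, and "the series" means these few. Any claim that something is new, unique, unknown or untested is made for them only; others in the source may bear on it.

Working notes on the series, measured so far:
- compound 1 `COC(=O)c1c(NCc2ccc(OC)cc2)noc1-c1ccc([N+](=O)[O-])cc1`: "not determined" (no result reported)
- compound 2 `COC(=O)c1c(NCc2ccc(Cl)cc2)noc1-c1ccc(Cl)cc1Cl`: 176000 nM

The read-out throughout is an ADME assay on J774.A1 cells (Mus musculus) for cytotoxicity, read by MTT assay, with a stated time of 48 h; on this read-out higher numbers stand for lower toxicity in this test and lower numbers for higher toxicity in this test. In this assay, within the data shown here, compound 2 gives 176000 nM, and this is the only number available. Compound 1 has no result, so compound 2 cannot be ranked against anything and serves only as the reference point.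

The next compound is compound 3 `COC(=O)c1c(NCc2ccc(OC)cc2)noc1-c1ccc(Cl)cc1Cl`, which differs from compound 2 by methoxy in place of chloro on an aromatic carbon. This is methoxy in place of chloro on an aromatic carbon, para to a large group, and read one bond further out it is 4-chlorobenzyl to 4-methoxybenzyl. The rest of the molecule, including the shared core, stays the same.

Among the measured compounds shown here, the series offers no measured step between two compounds, so neither size nor direction can be taken from the data. No change beyond the usual scatter is expected in this assay, and the estimate is anchored on compound 2 at 176000 nM. The expected step is a 1.0-fold higher number from compound 2 to compound 3 (0.01 log units; within the scatter). For compound 3 the estimated value is 180000 nM, with an expected range of 80000 nM to 400000 nM.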

Compound 3, half-maximal cytotoxic concentration: 34700 nM
Estimate against measurement, compound 3: 5.2-fold (0.71 log units) above; the whole stated range lies above it.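

Working notes, continued. In this assay, the exchange of 4-chlorobenzyl for 4-methoxybenzyl, with the rest of the molecule unchanged, gives a 5.1-fold lower number from compound 2 to compound 3 (0.71 log units; beyond the scatter), so this position on the benzyl ring, para to a large group, has a measurable bearing on the read-out, and compound 3 is the more toxic of the pair in this test. Among these compounds, this is the first step that can be read, and it rests on one pair, so it gives a size and a direction for methoxy in place of chloro at this place only. Nothing available bears on why the number moves in this direction.

Steps involving compound 1 cannot be read, so it remains open whether the same exchange gives a step of similar size and direction when the dichlorophenyl part of the shared core is replaced. Also open, on these data alone, is how other groups at this place would read against compound 2 and compound 3, for example a fluoro, a hydroxyl, an amine, a carboxylic acid or a longer alkoxy chain.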